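The source may hold more compounds than are shown below. What is called first, only, known or untested is meant among the compounds shown, and "the series" means these compounds.

Measured compounds:
compound 1 `C=CCn1c(=O)/c(=C\c2cccc(Br)c2)[nH]c(=O)/c1=C\c1ccccc1OC` — 2400 nM
compound 2 `C=CCn1c(=O)/c(=C\c2cccc(Br)c2)[nH]c(=O)/c1=C\c1cccc(Br)c1` — "not active" (no number reported)
compound 3 `C=CCn1c(=O)/c(=C\c2cc(OC)c(OC)c(OC)c2)[nH]c(=O)/c1=C\c1cccc(Br)c1` — "not active" (no number reported)

Going by the values given here, in a functional assay on K562 cells (Homo sapiens) for cytotoxicity, read by CCK-8 assay, with a stated time of 72 h (on this read-out higher numbers stand for weaker inhibition and lower numbers for stronger inhibition), compound 1 gives 2400 nM and is the only compound with a number. Compound 2 is reported in this assay as "not active" (no number reported) without a number. Compound 3 likewise is reported as "not active" (no number reported) without a number. Compound 4 `C=CCn1c(=O)/c(=C\c2cc(Br)ccc2F)[nH]c(=O)/c1=C\c1ccccc1OC` differs from compound 1 by fluoro in place of hydrogen on an aromatic carbon. Among the compounds with values here, with no measured step of this kind available, the change is small and the expectation for this assay is a step that stays within the usual scatter, in no firm direction. The estimate for compound 4 is 2000 nM, within 800 nM to 6000 nM, an expected step of a 1.2-fold lower number from compound 1 to compound 4 (0.08 log units; within the scatter).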

Compound 4, half-maximal inhibitory concentration: 5100 nM
For compound 4 the middle estimate is 2.6-fold (0.41 log units) below the measured one, and the stated range covers the measured number.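

In this assay, going by these compounds alone, this is the first step that can be read at a single place: on the bromophenyl ring, a fluoro ortho to a large group and para to a bromo group gives a 2.1-fold higher number from compound 1 to compound 4 (0.33 log units; beyond the scatter). Even one fluorine atom at this carbon therefore moves the number beyond the usual scatter, though only modestly and towards weaker inhibition. No available evidence accounts for this shift.

On these data alone, whether chloro, a hydroxyl or an amine at this carbon would give a similar step remains open. So does whether fluoro would behave alike on the other carbons of this ring.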